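Methyl to Hydrogen on the Aromatic Ring: Awaiting a Read-out

This account rests on a few compounds, and the source may have more. Where it says the series, first, only, none or still open, it means among the compounds named here.

Of the compounds shown here, three built on a shared core have so far been measured in a functional assay on MCF7 cells (Homo sapiens), tested at 2.5 uM; on this read-out lower numbers stand for a stronger effect and higher numbers for a weaker effect at the one concentration tested. Compound 1, `C=CCOc1c(C)c(C)c2c(c1C)CCC(C)(COc1ccc(/C=C3\SC(=O)NC3=O)cc1Br)O2`, gives 102% in this assay. Compound 2, `CC(C)=CCOc1c(C)c(C)c2c(c1C)CCC(C)(COc1ccc(/C=C3\SC(=O)NC3=O)cc1C)O2`, gives 89% in this assay. Compound 3, `C=CCOc1c(C)c(C)c2c(c1C)CCC(C)(COc1cccc(/C=C3\SC(=O)NC3=O)c1)O2`, gives 84% in this assay.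

Compound 2 holds the second highest of the three numbers. Its value and that of compound 3 lie within the usual scatter of each other, so no order between them can be read from these data. Against compound 1 the gap is beyond the scatter: compound 1 shows the weaker effect of the two.

Compound 4, `CC(C)=CCOc1c(C)c(C)c2c(c1C)CCC(C)(COc1ccc(/C=C3\SC(=O)NC3=O)cc1)O2`, has not yet been measured in this assay. It differs from compound 2 in one place only: hydrogen in place of methyl on an aromatic carbon. Among the measured compounds shown here, no pair of measured compounds shows what such a change does in this assay, so the size of the step can only be guessed. Because compound 2 sits at 89% and the change is the loss of one small group, no step beyond the scatter is expected in either direction. Compound 4 is therefore expected to give about 91% in this assay, with a range from 77% to 105%. The expected step of a number 2 percentage points higher from compound 2 to compound 4 (within the scatter) is thus estimated to fall within the scatter.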

Compound 4, a percentage reported as activity, at one concentration (the size of the read-out at that concentration, not a potency): 76%
Beside the measured number, compound 4's estimate is 15 percentage points above it; measured number below the stated range.
By their numbers in this assay, from the lowest: compounds 4, 3 and 2 (each within the scatter of the next, the first and the last beyond it); then compound 1.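

Hydrogen in place of methyl on an aromatic carbon gives a number 13 percentage points lower from compound 2 to compound 4 (beyond the scatter) in this assay, the first step in this series that can be read at a single place. It shows that this position, ortho to a large group, is not indifferent to the change: losing one heavy atom is enough to move the read-out towards the stronger effect, with compound 2 the weaker of the pair. Nothing measured here bears on why the step occurs.

The compounds shown leave open whether this step depends on methyl itself or would recur with other groups on the same aromatic carbon, such as fluorine, a methoxy group or an ethyl group, and whether hydrogen in place of bromine on the core of compound 1 would give a step of similar size. They also leave open how far the step holds at other concentrations, as this assay reports the size of the read-out at one concentration and not a potency.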